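Swapping Methyl for Bromo on the Sulfonyl Ring

This account rests on a few compounds, and the source may have more. Where it says the series, first, only, none or still open, it means among the compounds named here.

Of the compounds shown here, three sharing one core have been tested in a functional assay on MDA-MB-231 cells (Homo sapiens) for inhibition, read by sulforhodamine B assay, tested at 10 uM; a lower number here means less inhibition, a higher number more inhibition at the concentration tested (going by the name of the read-out). Compound 1, `CC(=O)N1N=C(c2ccc(-n3cncn3)cc2)CC1c1ccc(N(C)C)cc1`, gives 7.4%. Compound 2, `COC(=O)CC(=O)N1N=C(c2ccc(-n3cncn3)cc2)CC1c1ccc(N(C)C)cc1`, gives 6.8%. Compound 3, `Cc1ccc(S(=O)(=O)N2N=C(c3ccc(-n4cncn4)cc3)CC2c2ccc(N(C)C)cc2)cc1`, gives 20.7%, the highest of the three numbers; the step of a number 13.3 percentage points higher from compound 1 to compound 3 (beyond the scatter) and the step of a number 13.9 percentage points higher from compound 2 to compound 3 (beyond the scatter) both lie beyond the scatter, while a number 0.6 percentage points lower from compound 1 to compound 2 (within the scatter) does not. The compound bearing a sulfonyl group on the ring nitrogen therefore stands apart from the two carrying a carbonyl there.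

Compound 4, `CN(C)c1ccc(C2CC(c3ccc(-n4cncn4)cc3)=NN2S(=O)(=O)c2ccc(Br)cc2)cc1`, has not yet been measured. It differs from compound 3 in one place: bromo in place of methyl on an aromatic carbon. For the measured compounds named here, none of the measured steps touches this ring; the two steps beyond the scatter both concern the exchange of an acetyl or a chain carbonyl for the sulfonyl, which compound 4 keeps. Going by the values given here, with no step of the same kind among the measured compounds, the expectation rests on compound 3 alone, and a step within the scatter, in either direction, seems most likely. Compound 4 is therefore expected to give roughly 22% in this assay, within a range from 8% to 38%, an estimated step of a number 1.3 percentage points higher from compound 3 to compound 4 (within the scatter).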

Compound 4, a percentage reported as inhibition, at one concentration (the size of the read-out at that concentration, not a potency): 10.4%
Compound 4: middle estimate off by 11.6 percentage points, on the high side; the measured number falls inside the stated range.
By their numbers in this assay, from the lowest: compounds 2, 1 and 4 (each within the scatter of the next); then compound 3.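

In this assay the step of a number 10.3 percentage points lower from compound 3 to compound 4 (beyond the scatter) shows that the group para to a large group on the sulfonyl ring can move the number, even though methyl and bromo are each a single heavy atom with no hydrogen-bond donors or acceptors. The earlier picture of a sulfonyl compound standing apart from the carbonyl compounds also no longer holds as a general rule: the steps of a number 3.6 percentage points higher from compound 2 to compound 4 (within the scatter) and a number 3 percentage points higher from compound 1 to compound 4 (within the scatter) leave compound 4 among the carbonyl compounds, so among these compounds only the (4-methylphenyl)sulfonyl group stands apart, and the (4-bromophenyl)sulfonyl group goes against any rule for sulfonyl groups as a whole. Nothing available here explains the difference between methyl and bromo.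

Still open, from the compounds shown here alone, is whether the higher number belongs to methyl alone or extends to other groups at this place, such as ethyl, methoxy or chloro, or to a phenyl ring carrying only hydrogen there. Going by these compounds, each number also comes from a single concentration, so how these compounds compare in potency remains open.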